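The source may hold more compounds than are shown below. What is called first, only, known or untested is meant among the compounds shown, and "the series" means these compounds.

Values from an ADME assay on HEK293 cells (Homo sapiens) for inhibition, read by MTT assay, with stated times of 18 h and 4 h (on this read-out higher numbers stand for weaker inhibition and lower numbers for stronger inhibition), follow
- Compound 1 `CCCCCCCCOP(=O)(O)OCCSC(=S)N1CCCCC1` gives 69000 nM
- Compound 2 `CCCCCCCCCCCCCCCCOP(=O)(O)OCCSC(=S)N1CCN(C)CC1` gives > 100000 nM as a limit
- Compound 3 `CCCCCCCCCCOP(=O)(O)OCCSC(=S)N1CCCCC1` gives 70700 nM

Compound 3, with 70700 nM in this assay stands level with compound 1, within the scatter. Compound 2 gave only a limit, the one noted in the limit of > 100000 nM in this assay, at which 1 of the 3 values shown sits, and not a number.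

Compound 4 `CCCCCCCCCCCCCCCCOP(=O)(O)OCCSC(=S)N1CCCCC1` differs from compound 3 by hexyl in place of hydrogen on a saturated chain carbon, ten or more bonds along the chain from an oxygen on an unsaturated carbon and nothing else. For the measured compounds named here, the one measured step along this chain is a 1.0-fold higher number from compound 1 to compound 3 (0.01 log units; within the scatter) and it stayed within the scatter, though it added only ethyl, so the longer hexyl calls for wide margins. The estimated step is a 1.0-fold lower number from compound 3 to compound 4 (0.00 log units; within the scatter) and so no shift beyond the scatter is expected in this assay here. For compound 4 the estimated value is 70000 nM with an expected range from 35000 nM to 100000 nM overall.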

Compound 4, half-maximal inhibitory concentration: > 100000 nM
Compound 4 ended at the assay's limit; the forecaster's own chance of this, stated with the estimate: 25%; middle value at least 1.4-fold (0.15 log units) away from the limit.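

A longer addition at this place on the saturated chain gives a limit rather than a number, which the ethyl step did not do. Hexyl gives an at least 1.4-fold higher number from compound 3 to compound 4 (0.15 log units; that floor lies within the scatter), and octyl gives an at least 1.4-fold higher number from compound 1 to compound 4 (0.16 log units; that floor lies within the scatter); these are floors, so neither step is shown to clear the scatter, and the true sizes remain unknown. The step between the two compounds at a limit cannot be read: the limit of > 100000 nM in this assay, at which 2 of the 4 values shown sit.

From the compounds shown here alone, whether a dodecyl chain would still give a number remains open. So does the effect of swapping piperidin-1-yl for 4-methylpiperazin-1-yl on a shorter chain such as decyl.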